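Replacing the chlorophenyl with a sulfonamide-bearing phenyl

This account rests on a few compounds, and the source may have more. Where it says the series, first, only, none or still open, it means among the compounds named here.

Compound 3 `O=C(O)Cc1sc(C(c2ccc(F)cc2)c2ccc(F)cc2)nc1-c1ccc(Cl)cc1` gives 9.7 nM in an in vitro assay on HEK385-7 cells for displacement of a labelled ligand from prostaglandin D2 receptor 2 (Homo sapiens); a lower number here means a stronger inhibitor, a higher number a weaker inhibitor. Compound 2 `O=C(O)Cc1sc(C(c2ccccc2)c2ccc(F)cc2)nc1-c1ccc(Cl)cc1` gives 17 nM, and the difference is a 1.8-fold lower number from compound 2 to compound 3 (0.24 log units; within the scatter). Compound 1 `O=C(O)Cc1sc(COc2ccc(Cl)cc2)nc1-c1ccc(Cl)cc1` gives 32 nM, a gap to compound 3 that lies beyond the scatter. Compound 4 `CS(=O)(=O)Nc1cccc(-c2nc(C(c3ccc(F)cc3)c3ccc(F)cc3)sc2CC(=O)O)c1` is derived from compound 3 by the change (3-(methanesulfonamido)phenyl in place of 4-chlorophenyl on an aromatic carbon). Going by the values given here, none of the measured steps touches this position: the only step in hand concerns a fluoro on one of the two phenyl groups of the large substituent, so it offers no guide to the new 3-(methanesulfonamido)phenyl. With nothing to point either way, the expectation is a step of a 1.0-fold higher number from compound 3 to compound 4 (0.01 log units; within the scatter), within the scatter. Compound 4 is therefore estimated at 10 nM in this assay, between 3 nM and 40 nM.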

Compound 4, half-maximal inhibitory concentration: 40 nM
Compound 4: the middle estimate sits 4.0-fold (0.60 log units) below what was measured; measured number inside the range.
By their numbers in this assay, from the lowest: compounds 3, 2, 1 and 4 (each within the scatter of the next, the first and the last beyond it).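

In this assay, going by these compounds alone, putting 3-(methanesulfonamido)phenyl in place of 4-chlorophenyl gives a 4.1-fold higher number from compound 3 to compound 4 (0.62 log units; beyond the scatter), whereas the only earlier step, the fluoro change, stayed within the scatter. This aromatic carbon therefore responds to the group it carries, though the shift is modest for an exchange of one substituted phenyl for a quite different one. Nothing measured here explains the shift. As far as these compounds go, it remains open whether a plain phenyl or an amine on the phenyl would stand nearer compound 3 or compound 4. From the compounds shown here alone, the same step on the core of compound 1 is also open.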